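The source may hold more compounds than are shown below. What is called first, only, known or untested is meant among the compounds shown, and "the series" means these compounds.

The series shares one core, carried by compound 1 `CC1=C(C(=O)OCc2cccnc2)C(c2ccccc2[N+](=O)[O-])C2=C(CCCC2=O)N1`, compound 2 `CC1=C(C(=O)OCc2ccccn2)C(c2ccco2)C2=C(CCCC2=O)N1`, compound 3 `CC1=C(C(=O)OCc2ccccn2)C(c2ccc(Br)cc2)C2=C(CCCC2=O)N1` and the as yet unmeasured compound 4 `CC1=C(C(=O)OCc2ccccn2)C(c2ccc(Cl)cc2)C2=C(CCCC2=O)N1`. In a physicochemical assay for lipophilicity, measured as octanol-water partition (a higher number here means a more lipophilic compound, a lower number a more polar compound), compound 1 gives 1.51, compound 2 gives 1.4 and compound 3 gives 2.42. Compound 2 thus holds the lowest of the three numbers, though its gap to compound 1 lies within the scatter, so only compound 3 stands clearly apart from it.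

Compound 4 differs from compound 2 in one place: 4-chlorophenyl in place of furan-2-yl on a saturated ring carbon. Within the data shown here, one measured step bears on this change: a number 1.02 log units higher from compound 2 to compound 3 (beyond the scatter), in which a 4-bromophenyl rather than a 4-chlorophenyl replaced the furan-2-yl on the same saturated ring carbon. Both steps exchange a five-membered aromatic ring bearing one oxygen for a six-membered ring of carbon only that carries a halogen, so a large rise in this assay is expected for compound 4 as well, of a size close to, but estimated to fall a little short of, the step to compound 3. On that basis the step from compound 2 to compound 4 is expected to be a number 0.85 log units higher from compound 2 to compound 4 (beyond the scatter). Compound 4 is therefore estimated at 2.25 in this assay, with a range from 1.95 to 2.55.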

Compound 4, partition coefficient: 2.24
Compound 4: middle estimate off by 0.01 log units, on the high side, within the range that was stated.
By their numbers in this assay, from the lowest: compounds 2 and 1 (each within the scatter of the next); then compounds 4 and 3 (each within the scatter of the next).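

Compound 4 gives the exchange of furan-2-yl on this saturated ring carbon a second reading in this assay, with a number 0.84 log units higher from compound 2 to compound 4 (beyond the scatter), so the large rise seen with the 4-bromophenyl group is no longer a single observation. The new comparison also isolates the halogen on the aromatic carbon: with a number 0.18 log units lower from compound 3 to compound 4 (within the scatter), chloro and bromo cannot be told apart in this assay, and for these two compounds the rise over compound 2 does not depend on which of the two halogens is present. No measured evidence is available to explain either step.

The compounds shown leave open how the rise divides between the six-membered ring of carbon only and the halogen it carries, a question that a plain phenyl group on the same saturated ring carbon would address. As far as these compounds go, it also remains open whether the step would keep its size with a different kind of group at the same place on that aromatic ring, such as an amine or a carboxylic acid.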